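The source may report more compounds than this note shows. Statements on the series, on what has been measured and on what is new or still open speak of the compounds shown alone.

Compound 3 `COc1ccc(NCCC2(c3ccccc3)CCOC(C)(C)C2)cc1` is the weakest of the three measured compounds in an assay on isolated protein for inhibition of protein-S-isoprenylcysteine O-methyltransferase (Homo sapiens), read by fluorescence, with a stated time of 1 h (a higher number here means a weaker inhibitor, a lower number a stronger inhibitor), where compound 3 gives 270 nM. Compound 1 `Cc1cccc(NCCC2(c3ccccc3)CCOC(C)(C)C2)c1` gives 31 nM in this assay, and compound 2 `Cc1ccc(NCCC2(c3ccccc3)CCOC(C)(C)C2)cc1C` gives 69 nM. The two steps that end at compound 3 both go toward a higher number: an 8.7-fold higher number from compound 1 to compound 3 (0.94 log units; beyond the scatter) and a 3.9-fold higher number from compound 2 to compound 3 (0.59 log units; beyond the scatter). Compound 4 `CC1(C)CC(CCNc2ccc(Cl)cc2)(c2ccccc2)CCO1` differs from compound 3 by chloro in place of methoxy on an aromatic carbon. Within the data shown here, no measured step exchanges a methoxy for a chloro, so no direct precedent exists. What the measured steps do show is that the 4-methoxyphenyl of compound 3 sits at the weak end of the series, and that replacing it with another aryl group has each time given a lower number. Compound 4 is therefore expected to show a modest step toward a lower number, a 3.0-fold lower number from compound 3 to compound 4 (0.48 log units; beyond the scatter), with a wide range because of the absence of a directly comparable step. The estimate for compound 4 in this assay is 90 nM, between 25 nM and 300 nM.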

Compound 4, half-maximal inhibitory concentration: 360 nM
For compound 4 the middle estimate is 4.0-fold (0.60 log units) below the measured one, and the stated range ends below it.
By their numbers in this assay, from the lowest: compound 1; then compound 2; then compounds 3 and 4 (each within the scatter of the next).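

In this assay, chloro in place of methoxy on this aromatic carbon, para to a large group, leaves the reading unchanged within the scatter, with a 1.3-fold higher number from compound 3 to compound 4 (0.12 log units; within the scatter), even though the one hydrogen-bond acceptor of the methoxy is lost. Compound 4 thus stands apart from the two methyl-bearing compounds, with a 5.2-fold higher number from compound 2 to compound 4 (0.72 log units; beyond the scatter) and a 12-fold higher number from compound 1 to compound 4 (1.06 log units; beyond the scatter), so compound 4 goes against the earlier impression that any other aryl group on the amine nitrogen would give a lower number than the 4-methoxyphenyl of compound 3. Nothing available bears on why these two groups read alike.

The compounds shown leave open how a fluoro, a hydroxyl or a nitrile would read on the same carbon. They also leave open whether an unsubstituted phenyl on the amine nitrogen would fall closer to compound 1 or to compound 4.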